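The source may report more compounds than this note shows. Statements on the series, on what has been measured and on what is new or still open speak of the compounds shown alone.

Measured so far:
compound 1 `CCCCNc1nc(N)nc2c1CN(C(=O)c1ccccc1)CC2` — in an assay on HEK293 cells for agonist activity at Toll-like receptor 8 (Homo sapiens), read by a luciferase reporter, with a stated time of 6 h (on this read-out lower numbers stand for an effect already at smaller amounts and higher numbers for an effect only at larger amounts of compound), compound 1 gives 1.4 uM
compound 2 `CCCCNc1nc(N)nc2c1CN(C(=O)c1cnccn1)CC2` — in this assay compound 2 gives 2.2 uM

Compound 2 holds the higher of the two numbers, but the gap between them is a 1.6-fold higher number from compound 1 to compound 2 (0.20 log units; within the scatter), so the two cannot be ordered. Compound 3 `CCCCNc1nc(N)nc2c1CN(C(=O)c1cc(C)on1)CC2` differs from compound 2 by 5-methyl-1,2-oxazol-3-yl in place of pyrazin-2-yl on a carbonyl carbon. Going by the values given here, only one measured step bears on swapping the ring on the carbonyl carbon, namely a 1.6-fold higher number from compound 1 to compound 2 (0.20 log units; within the scatter), and it stayed within the scatter. A step of similar small size, in no certain direction, is therefore expected in this assay. Compound 3 is estimated at 2 uM (range 0.8 uM to 5 uM), an expected step of a 1.1-fold lower number from compound 2 to compound 3 (0.04 log units; within the scatter).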

Compound 3, minimum effective concentration: 0.4 uM
Compound 3: middle estimate off by 5.0-fold (0.70 log units), on the high side; measured number below the stated range.
By their numbers in this assay, from the lowest: compound 3; then compounds 1 and 2 (each within the scatter of the next).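

The ring on the carbonyl carbon is not a silent place in this assay: the swap gives a 5.5-fold lower number from compound 2 to compound 3 (0.74 log units; beyond the scatter) and, against phenyl, a 3.5-fold lower number from compound 1 to compound 3 (0.54 log units; beyond the scatter) while phenyl and pyrazin-2-yl stay inseparable. Both six-membered rings thus sit on the same side of the five-membered 5-methyl-1,2-oxazol-3-yl. No evidence on why the number moves is available here.

Open, from the compounds shown here alone, is whether an unsubstituted 1,2-oxazol-3-yl or a 5-ethyl-1,2-oxazol-3-yl would hold this number. Until then, the step cannot be assigned to the ring or to its methyl.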